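A few compounds are considered here, and "the series" means these few. Any claim that something is new, unique, unknown or untested is made for them only; others in the source may bear on it.

Measured in a functional assay on PC-3 cells (Homo sapiens) for inhibition, read by MTT assay, with a stated time of 48 h, tested at 10 uM; on this read-out higher numbers stand for more inhibition of growth at the one concentration tested and lower numbers for less inhibition of growth
compound 1 `Cc1cc(=O)c2c(O)cc(OCc3ccco3)c([C@H]3CCN(C)C[C@H]3O)c2o1` gives 14%
compound 2 `Cc1cc(=O)c2c(O)cc(O)c([C@H]3CCN(C)C[C@H]3OC(=O)c3ccco3)c2o1` gives 23%
compound 3 `Cc1oc2c([C@H]3CCN(C)C[C@H]3O)c(O)cc(O)c2c(=O)c1C(O)c1ccccc1Br` gives 45%

Compound 3 stands highest of the three, beyond the scatter from both compound 2 and compound 1. Compound 4 `COc1ccc(C(O)c2c(C)oc3c([C@H]4CCN(C)C[C@H]4O)c(O)cc(O)c3c2=O)cc1Br` differs from compound 3 by 3-bromo-4-methoxyphenyl in place of 2-bromophenyl on a saturated chain carbon bound to an aromatic carbon and an oxygen on a saturated carbon (3-bromo-4-methoxyphenyl in place of 2-bromophenyl, on a saturated chain carbon bound to an aromatic carbon and an oxygen on a saturated carbon). Among the measured compounds shown here, no measured step in this assay isolates this change. The expectation rests on compound 3 at 45% alone, and no move beyond the scatter is expected. The estimated step is a number 5 percentage points lower from compound 3 to compound 4 (within the scatter) (a slight fall at most). Compound 4 is expected at 40% (range 22% to 58%).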

Compound 4, percent growth inhibition at one concentration: 0%
For compound 4 the middle estimate is 40 percentage points above the measured one, outside the stated range (below it).
By their numbers in this assay, from the lowest: compound 4; then compounds 1 and 2 (each within the scatter of the next); then compound 3.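

In this assay, among the compounds shown here, the aryl group on the saturated chain carbon proves to be a sensitive point: 3-bromo-4-methoxyphenyl in place of 2-bromophenyl gives a number 45 percentage points lower from compound 3 to compound 4 (beyond the scatter) and is the only single-place step. Compound 4 gives 0% at the one concentration tested, so growth inhibition here depends strongly on this aryl group. Nothing available accounts for the loss.

The step alters the bromine's place and adds methoxy together, so their shares remain unseparated. As far as these compounds go, whether 3-bromophenyl or 4-methoxyphenyl alone, or a 4-aminophenyl group, would retain inhibition stays open.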